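Trading 3-(1-hydroxyethyl)phenyl for 4-acetylphenyl on a carbonyl carbon

This account rests on a few compounds, and the source may have more. Where it says the series, first, only, none or still open, it means among the compounds named here.

Only a little is known so far about this small set of compounds. In an ADME assay on L02 cells (Homo sapiens) for cytotoxicity, read by CCK-8 assay, with a stated time of 6 days (a higher number here means a weaker inhibitor, a lower number a stronger inhibitor), compound 1 `CC(=O)c1cc(C(=O)N[C@H](C)Cn2ccc(-c3cc(F)c(C#N)c(Cl)c3)n2)n[nH]1` is recorded as "not determined" (no result reported). Compound 2 `CC(O)c1cccc(C(=O)N[C@@H](C)Cn2ccc(-c3ccc(C#N)c(Cl)c3)n2)c1` is likewise recorded in this assay as "not determined" (no result reported), so it offers no number to start from. Compound 3 `C[C@@H](Cn1ccc(-c2ccc(C#N)c(Cl)c2)n1)NC(=O)c1cccc(OCC(O)CO)c1` gives > 30000 nM in this assay, and this is a limit of the assay, not a number.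

The next compound to be measured is compound 4 `CC(=O)c1ccc(C(=O)N[C@@H](C)Cn2ccc(-c3ccc(C#N)c(Cl)c3)n2)cc1`. The structural change is 4-acetylphenyl in place of 3-(1-hydroxyethyl)phenyl on a carbonyl carbon. In plain terms, 4-acetylphenyl takes the place of 3-(1-hydroxyethyl)phenyl on a carbonyl carbon, while the rest of the molecule stays the same.

For the measured compounds named here, no pair of measured compounds shows what a swap of this kind does in this assay. Going by the values given here, with no measured step to go on, the expectation is for no step beyond the usual scatter. Among the compounds with values here, the only reading to lean on is the limit of compound 3 at > 30000 nM. A similar limit would therefore be no surprise for the new compound. For compound 4 the expected value is 30000 nM, with an estimated range from 12000 nM to 60000 nM.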

Compound 4, half-maximal inhibitory concentration: 15300 nM
Compound 4: middle estimate off by 2.0-fold (0.29 log units), on the high side; low and high end bracket the measured number.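

In this assay compound 4 gives 15300 nM while compound 2 offers no number, so no step can be read between these two compounds. The compounds shown leave open what exchanging 3-(1-hydroxyethyl)phenyl for 4-acetylphenyl on this carbonyl carbon does in this assay. Nothing shown bears on why compound 4 gives this value.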